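Benzimidazole amides: bromo for methoxy in two places

The source may report more compounds than this note shows. Statements on the series, on what has been measured and on what is new or still open speak of the compounds shown alone.

Measured so far, in a functional assay on MCF7 cells (Homo sapiens) for inhibition, read by MTT assay, with a stated time of 24 h; a higher number here means a weaker inhibitor of growth, a lower number a stronger inhibitor of growth:
compound 1, `COc1ccccc1C(=O)n1c(-c2cn(C)c3ccccc23)nc2ccccc21`, gives 32100 nM;
compound 2, `Cn1cc(-c2nc3ccccc3n2C(=O)c2ccccc2Br)c2ccccc21`, gives 70100 nM;
compound 3, `COc1ccc2c(c1)c(-c1nc3ccccc3n1C(=O)c1ccccc1)cn2C`, gives 38400 nM.

Compound 1 and compound 2 differ by bromo in place of methoxy on an aromatic carbon; this gave a 2.2-fold higher number from compound 1 to compound 2 (0.34 log units; beyond the scatter). Compound 3 has the same atoms as compound 1 joined differently; the difference between the two cores is not broken down here. The values of compound 3 and compound 1 lie within the scatter of each other, as do those of compound 3 and compound 2.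

Compound 4, `Cn1cc(-c2nc3ccccc3n2C(=O)c2ccccc2)c2cc(Br)ccc21`, has not yet been measured. It differs from compound 3 by bromo in place of methoxy on an aromatic carbon. This is the same kind of change as that from compound 1 to compound 2, but the surroundings differ: there the place was on a six-membered aromatic ring of carbon only, ortho to a large group; here it is on a six-membered aromatic ring of carbon only, part of a fused or bridged system of two rings, meta to a fused ring and para to a fused ring.

Because the earlier change gave a 2.2-fold higher number from compound 1 to compound 2 (0.34 log units; beyond the scatter), a step of similar size is expected in this assay for compound 4, namely a 1.8-fold higher number from compound 3 to compound 4 (0.26 log units; within the scatter), with wide uncertainty since the surroundings of the change are not the same. Compound 4 is therefore estimated at 70000 nM, between 30000 nM and 160000 nM.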

Compound 4, concentration for 50% growth inhibition: 50300 nM
Estimate against measurement, compound 4: 1.4-fold (0.14 log units) above; measured number inside the range.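

In this assay, bromo in place of methoxy on the core of compound 3 gives a 1.3-fold higher number from compound 3 to compound 4 (0.12 log units; within the scatter), whereas the same exchange on the core of compound 1 gives a 2.2-fold higher number from compound 1 to compound 2 (0.34 log units; beyond the scatter). The two steps point the same way on paper, but they cannot be told apart: the same change on two cores in this assay, a 2.2-fold higher number (0.34 log units; beyond the scatter) from compound 1 to compound 2 and a 1.3-fold higher number (0.12 log units; within the scatter) from compound 3 to compound 4, 1.7-fold (0.22 log units) apart, within the scatter of two such steps. Within the data shown here, this shows no detectable difference in how the change carries from one core to the other, but it does not show that the step is transferable: only two pairs stand here, the change sits at a different place in each, and the step on the core of compound 3 on its own cannot be told from no change.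

Still open, on these data alone, is whether the two cores would give matching steps with the change made at the same place on each. Also open, as far as these compounds go, is whether other groups at these places, such as an amine, a carboxylic acid or a longer alkoxy chain, would give a step beyond the scatter on either core.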